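The source may hold more compounds than are shown below. What is called first, only, known or untested is meant among the compounds shown, and "the series" means these compounds.

In an ADME assay on microsomes from liver (Mus musculus) for metabolic stability, read by LC-MS, using NADPH, with a stated time of 60 min, tested at 1 uM (on this read-out higher numbers stand for a longer-lived compound and lower numbers for a shorter-lived compound), compound 1 `O=S(=O)(c1cccc(C(F)(F)F)c1)N1CCc2ccc(OCc3c(F)cccc3Cl)cc21` gives 0.0483 h. For the measured compounds named here, compound 2 `O=S(=O)(c1cccc(C(F)(F)F)c1)N1CCc2ccc(-c3cc(F)cc(OC(F)F)c3)cc21` gives 0.19 h, the higher of the two numbers so far. The step between them is a 3.9-fold higher number from compound 1 to compound 2 (0.59 log units; beyond the scatter), and it comes with 3-(difluoromethoxy)-5-fluorophenyl in place of (2-chloro-6-fluorobenzyl)oxy on an aromatic carbon.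

Compound 3 `O=C(O)CC1Cc2ccc(-c3cc(F)cc(OC(F)F)c3)cc2N1S(=O)(=O)c1cccc(C(F)(F)F)c1` keeps everything in compound 2 except for one change, carboxymethyl in place of hydrogen on a saturated ring carbon, next to the ring nitrogen: carboxymethyl in place of hydrogen on a saturated ring carbon. Going by the values given here, no measured pair carries this change. Among the compounds with values here, the single measured step lies at another place on the shared core, so it serves only as a gauge of size, and that gauge is the modest 3.9-fold higher number from compound 1 to compound 2 (0.59 log units; beyond the scatter). Within the data shown here, a step of similar size is expected in this assay, towards a longer-lived compound, though the direction is a judgement that no measured pair tests. The estimated change is a 3.2-fold higher number from compound 2 to compound 3 (0.50 log units; beyond the scatter). For compound 3 the half-life is estimated at 0.6 h, with an expected range from 0.2 h to 1.8 h.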

Compound 3, half-life in the Mus musculus assay: 1.88 h
For compound 3 the middle estimate is 3.1-fold (0.50 log units) below the measured one; the whole stated range lies below it.
By their numbers in the Mus musculus assay, from the lowest: compound 1; then compound 2; then compound 3.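

For the compounds shown here, until now this saturated ring carbon, next to the ring nitrogen, had carried only hydrogen, so the position had no measured step of its own. In the Mus musculus assay, carboxymethyl in place of that hydrogen now gives a 9.9-fold higher number from compound 2 to compound 3 (1.00 log units; beyond the scatter), which shows that a change at this carbon can shift the half-life by an amount beyond the scatter, just as the earlier change at another place on the shared core did. In a physicochemical assay for solubility, read by LC-MS, in phosphate buffer, measured as kinetic solubility, with a stated time of 120 min, at pH 7.46, tested at 100 uM (on this read-out higher numbers stand for higher solubility and lower numbers for lower solubility), compound 2 gives 1480 nM and compound 3 gives 69400 nM. In the physicochemical assay, the same change also goes with a rise in solubility, so in this one pair a single substitution raises both read-outs: the measured solubility of compound 2, 1480 nM, and of compound 3, 69400 nM, a 47-fold higher number (1.67 log units; beyond the scatter)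

A single pair cannot show whether the carboxylic acid or the added chain as a whole accounts for these steps, and a methyl ester, a primary amide or a longer chain ending in a carboxylic acid at the same carbon would help to separate the two. From the compounds shown here alone, it also remains open whether carboxymethyl at this carbon would give similar steps with (2-chloro-6-fluorobenzyl)oxy in place of 3-(difluoromethoxy)-5-fluorophenyl.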